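The source may hold more compounds than are shown below. What is called first, only, known or untested is meant among the compounds shown, and "the series" means these compounds.

Working notes on the pyrazoline carbamate series.

Compound 1 `COC(=O)N1N=C(c2ccccc2)CC1c1cc(OC)c(OC)c(OC)c1` is the reference point; in a functional assay on HeLa cells (Homo sapiens) for antiproliferative activity, read by MTT assay, with a stated time of 48 h (on this read-out higher numbers stand for weaker inhibition of growth and lower numbers for stronger inhibition of growth), compound 1 gives 2180 nM. Compound 2 `CCOC(=O)N1N=C(c2ccccc2)CC1c1cc(OC)c(OC)c(OC)c1` carries the change (methyl in place of hydrogen on a saturated chain carbon bound to an oxygen next to a carbonyl group), and in this assay compound 2 gives 8230 nM. The step is a 3.8-fold higher number from compound 1 to compound 2 (0.58 log units; beyond the scatter). Compound 3 `COC(=O)N1N=C(c2cccc(OC)c2)CC1c1cc(OC)c(OC)c(OC)c1` carries the change methoxy in place of hydrogen on an aromatic carbon relative to compound 1, and in this assay compound 3 gives 1530 nM; the step is a 1.4-fold lower number from compound 1 to compound 3 (0.15 log units; within the scatter), so no order between compound 1 and compound 3 can be read from these two numbers. Against compound 2, the number for compound 3 is lower by a margin that does lie beyond the scatter, but no step is broken down here for that pair.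

Compound 4 `CCOC(=O)N1N=C(c2cccc(OC)c2)CC1c1cc(OC)c(OC)c(OC)c1` has not yet been measured in this assay. It differs from compound 3 by methyl in place of hydrogen on a saturated chain carbon bound to an oxygen next to a carbonyl group, which is the same change as that from compound 1 to compound 2, made on the same kind of place. The two cores differ by methoxy in place of hydrogen on an aromatic carbon. Given that the single earlier instance of this change produced a 3.8-fold higher number from compound 1 to compound 2 (0.58 log units; beyond the scatter), and that the core difference between compound 1 and compound 3 gave only a 1.4-fold lower number from compound 1 to compound 3 (0.15 log units; within the scatter), the step from compound 3 to compound 4 is expected to be of similar size, roughly a 3.8-fold higher number from compound 3 to compound 4 (0.58 log units; beyond the scatter). Compound 4 is therefore estimated at 5800 nM in this assay, with a range from 2500 nM to 13000 nM, resting on one prior pair only.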

Compound 4, concentration for 50% growth inhibition: 4110 nM
Compound 4: middle estimate off by 1.4-fold (0.15 log units), on the high side; the measured number falls inside the stated range.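

In this assay, methoxycarbonyl to ethoxycarbonyl on the core of compound 3 gives a 2.7-fold higher number from compound 3 to compound 4 (0.43 log units; beyond the scatter), and this step matches the one seen on the core of compound 1: the same change on two cores in this assay, a 3.8-fold higher number (0.58 log units; beyond the scatter) from compound 1 to compound 2 and a 2.7-fold higher number (0.43 log units; beyond the scatter) from compound 3 to compound 4, 1.4-fold (0.15 log units) apart, within the scatter of two such steps. The methoxy in place of hydrogen on an aromatic carbon, now read on the core of compound 2, gives a 2.0-fold lower number from compound 2 to compound 4 (0.30 log units; within the scatter), and this step also agrees with its earlier counterpart: the same change on two cores in this assay, a 1.4-fold lower number (0.15 log units; within the scatter) from compound 1 to compound 3 and a 2.0-fold lower number (0.30 log units; within the scatter) from compound 2 to compound 4, 1.4-fold (0.15 log units) apart, within the scatter of two such steps. Within these four compounds the two changes therefore carry from one core to the other without a detectable difference in step size, but this rests on a single pair of cores that differ in one group, and it shows neither that the ethoxycarbonyl step holds on cores that differ in other ways nor why the step occurs.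

The compounds shown leave open whether the trend from methoxycarbonyl to ethoxycarbonyl continues to a longer chain such as propoxycarbonyl or butoxycarbonyl. They also leave open how either carbamate would behave on a core bearing an amine or a carboxylic acid in place of the added methoxy.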